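The compounds below may be only part of what the source reports. "The series", "measured", "known", "first", "only" and "open" are said of these compounds alone.

In a physicochemical assay for solubility, read by HPLC, in phosphate buffer, measured as kinetic solubility, at pH 7.4 (a higher number here means a more soluble compound, a lower number a less soluble compound), compound 1 (`CCC(=O)c1cc(-c2ccc(S(N)(=O)=O)cc2)n(-c2ccc(Cl)cc2)n1`) gives 41900 nM, compound 2 (`NS(=O)(=O)c1ccc(-c2cc(C(=O)C3CC3)nn2-c2ccc(Cl)cc2)cc1`) gives 25600 nM and compound 3 (`NS(=O)(=O)c1ccc(-c2cc(C(=O)C3CCC3)nn2-c2ccc(Cl)cc2)cc1`) gives 17200 nM. Compound 3 thus lies within the scatter of compound 2 and beyond the scatter on the low side of compound 1. Compound 4 (`NS(=O)(=O)c1ccc(-c2cc(C(=O)CC3CCC3)nn2-c2ccc(Cl)cc2)cc1`) differs from compound 3 by cyclobutylmethyl in place of cyclobutyl on a carbonyl carbon, with cyclobutylmethyl in place of cyclobutyl on a carbonyl carbon. The nearest measured changes at this carbonyl carbon are a 1.5-fold lower number from compound 2 to compound 3 (0.17 log units; within the scatter) and a 2.4-fold lower number from compound 1 to compound 3 (0.39 log units; beyond the scatter), the first within the scatter and the second modest. A small drop, probably within the scatter, is therefore expected in this assay. The expected change is a 1.4-fold lower number from compound 3 to compound 4 (0.16 log units; within the scatter). For compound 4 the estimated value is 12000 nM, with an expected range of 6000 nM to 22000 nM.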

Compound 4, solubility: 4300 nM
Estimate against measurement, compound 4: 2.8-fold (0.45 log units) above; the measured number lies below the stated range.
By their numbers in this assay, from the lowest: compound 4; then compounds 3, 2 and 1 (each within the scatter of the next, the first and the last beyond it).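

In this assay the four-membered ring stays and cyclobutylmethyl enters on the carbonyl carbon, giving a 4.0-fold lower number from compound 3 to compound 4 (0.60 log units; beyond the scatter) as the step, so a change that keeps the ring still moves the number beyond the scatter. Compound 4 also stands apart from the other two compounds, with a 6.0-fold lower number from compound 2 to compound 4 (0.77 log units; beyond the scatter) and a 9.7-fold lower number from compound 1 to compound 4 (0.99 log units; beyond the scatter) as the steps, the last being the largest seen at this carbonyl carbon. No evidence on the cause of these steps is available.

Still open, on these data alone, is whether a longer chain on this carbonyl carbon lowers the number further, and whether an amine or a carboxylic acid in place of cyclobutylmethyl reverses the fall.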